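Diamino fused core: linker swap at the phenyl-bearing position

The source may hold more compounds than are shown below. What is called first, only, known or untested is meant among the compounds shown, and "the series" means these compounds.

Measured so far, in a functional assay on PC-3 cells (Homo sapiens) for inhibition, read by sulforhodamine B assay, with a stated time of 48 h; a higher number here means a weaker inhibitor of growth, a lower number a stronger inhibitor of growth:
- compound 1 `Nc1cc(N)c2nc(-c3ccccc3)c(Oc3ccc(Cl)c(Cl)c3)nc2c1` gives 14500 nM
- compound 2 `COc1ccc(CNc2nc3cc(N)cc(N)c3nc2-c2ccccc2)cc1OC` gives 27500 nM
- compound 3 `Nc1cc(N)c2nc(-c3ccccc3)c(NCc3ccc(F)cc3)nc2c1` gives 15500 nM

Compound 3 sits second highest of the three numbers; its nearest neighbour is compound 1, a 1.1-fold higher number from compound 1 to compound 3 (0.03 log units; within the scatter), and its furthest is compound 2, a 1.8-fold lower number from compound 2 to compound 3 (0.25 log units; within the scatter), so all three lie within the scatter of one another.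

Compound 4 `COc1ccc(Sc2nc3cc(N)cc(N)c3nc2-c2ccccc2)cc1` differs from compound 3 by (4-methoxyphenyl)sulfanyl in place of (4-fluorobenzyl)amino on an aromatic carbon. Going by the values given here, no measured step exchanges a nitrogen linker for a sulfur linker here. Among the compounds with values here, the only step that bears on it is the exchange of the whole side group at this same position, a 1.1-fold higher number from compound 1 to compound 3 (0.03 log units; within the scatter), which stayed within the scatter. On that basis compound 4 is expected to show no step beyond the scatter, a 1.0-fold higher number from compound 3 to compound 4 (0.01 log units; within the scatter). The estimate for compound 4 in this assay is 16000 nM, with a range from 5500 nM to 47000 nM.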

Compound 4, concentration for total growth inhibition: 5130 nM
The estimate for compound 4 lay 3.1-fold (0.49 log units) above the measured number, and the stated range ends above it.
By their numbers in this assay, from the lowest: compound 4; then compounds 1, 3 and 2 (each within the scatter of the next).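

In this assay the group at this position can move the number: (4-methoxyphenyl)sulfanyl gives a 3.0-fold lower number from compound 3 to compound 4 (0.48 log units; beyond the scatter) and, set against 3,4-dichlorophenoxy, a 2.8-fold lower number from compound 1 to compound 4 (0.45 log units; beyond the scatter) on the same aromatic carbon. Going by these compounds alone, the one earlier exchange here stayed within the scatter, so these are the first steps at this position to pass beyond it. Nothing at hand accounts for them.

The sulfur link and the methoxy group enter together, so the shown compounds do not separate their shares in the step. On these data alone, whether a (4-methoxyphenyl)amino group or a morpholine at this carbon would keep the lower number remains open.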